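Bromo in place of fluoro on compound 1

The source may hold more compounds than are shown below. What is called first, only, known or untested is meant among the compounds shown, and "the series" means these compounds.

compound 1 `O=C(NCc1ccc(NC(=O)c2cc(F)ccc2N2CCCC2)cc1)OCc1cccnc1`: 10700 nM
compound 2 `O=C(NCc1ccc(NC(=O)c2ccc(F)cc2N2CCCC2)cc1)OCc1cccnc1`: 52100 nM

In a functional assay on MGC-803 cells (Homo sapiens) for inhibition, read by MTT assay, with a stated time of 72 h (a higher number here means a weaker inhibitor, a lower number a stronger inhibitor), compound 1 holds the lower of the two numbers, and its gap to compound 2 lies beyond the usual scatter. Compound 3 `O=C(NCc1ccc(NC(=O)c2cc(Br)ccc2N2CCCC2)cc1)OCc1cccnc1` carries bromo in place of fluoro on an aromatic carbon, para to a pyrrolidin-1-yl group (bromo in place of fluoro on an aromatic carbon). Among the measured compounds shown here, no measured pair shows this exchange, so the expectation rests on compound 1 at 10700 nM alone. A small step toward a lower number, within the scatter, is expected: a 1.2-fold lower number from compound 1 to compound 3 (0.08 log units; within the scatter). Compound 3 is estimated at 9000 nM, with an expected range of 3500 nM to 24000 nM.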

Compound 3, half-maximal inhibitory concentration: 45700 nM
Beside the measured number, compound 3's estimate is 5.1-fold (0.71 log units) below it, and the stated range ends below it.
By their numbers in this assay, from the lowest: compound 1; then compounds 3 and 2 (each within the scatter of the next).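

In this assay, bromo in place of fluoro on the aromatic carbon para to a pyrrolidin-1-yl group gives a 4.3-fold higher number from compound 1 to compound 3 (0.63 log units; beyond the scatter). This shows that the number responds to the identity of the halogen at this position, with the fluoro of compound 1 giving the stronger inhibitor of this pair. Nothing in the data at hand explains the step. From the compounds shown here alone, whether chloro or an amine on this carbon would give a number closer to compound 1 or to compound 3 remains open.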